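The source may report more compounds than this note shows. Statements on the series, on what has been measured and on what is new or still open speak of the compounds shown alone.

Of the compounds shown here, three have been tested in an assay on Sf9 cells for inhibition of protein deacetylase HDAC6 (Homo sapiens), read by fluorescence, with a stated time of 40 min, tested at 100 nM; a higher number here means more inhibition at the concentration tested (going by the name of the read-out), a lower number less inhibition. Compound 1, `O=C(NO)c1ccc(NCc2nc(-c3ccco3)nn2-c2ccccc2)cc1`, gives 59.9%. Compound 3, `Cc1cccc(-n2nc(-c3ccccc3)nc2CNc2ccc(C(=O)NO)cc2)c1`, gives 66%, a number within the usual scatter of compound 1. Compound 2, `NC(=O)c1ccc(NCc2nc(-c3ccccc3)nn2-c2ccccc2)cc1`, gives only -4.4%, far below the other two. Compound 1 therefore stands second of the three, close to compound 3 and well clear of compound 2.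

Compound 4, `Cc1cccc(-c2nc(CNc3ccc(C(=O)NO)cc3)n(-c3ccccc3)n2)c1`, has not yet been measured in this assay. It differs from compound 1 in one place: 3-methylphenyl in place of furan-2-yl on an aromatic carbon. Within the data shown here, no measured pair shows this exact change, so the step is estimated from the two close values alone. The step is expected to be small, at most a slight rise, a number 4.1 percentage points higher from compound 1 to compound 4 (within the scatter), because compound 1 gives 59.9% and compound 3 gives 66%. Compound 4 is expected to give about 64%, between 45% and 80%.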

Compound 4, a percentage reported as inhibition, at one concentration (the size of the read-out at that concentration, not a potency): 64.1%
Compound 4: middle estimate off by 0.1 percentage points, on the low side; the range from low to high includes it.
By their numbers in this assay, from the lowest: compound 2; then compounds 1, 4 and 3 (each within the scatter of the next).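

In this assay, replacing furan-2-yl with 3-methylphenyl on this aromatic carbon gives a number 4.2 percentage points higher from compound 1 to compound 4 (within the scatter). Among these compounds, this is the first direct comparison at this position, and it shows that a six-membered carbon-only ring with no hydrogen-bond acceptor can stand in place of the furan-2-yl ring without a step beyond the scatter. No measured evidence on why this is so is available.

Both groups compared here are aromatic rings. On these data alone, whether a non-aromatic group at this position, such as an amine, a carboxylic acid or a longer alkyl chain, would give a similar reading remains open.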